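Halogen swap on the hydroxyphenyl hydrazone arm

The source may report more compounds than this note shows. Statements on the series, on what has been measured and on what is new or still open speak of the compounds shown alone.

Measured so far:
compound 1 `COc1ccc(OC)c(/C=N/NC(=O)Nc2ccc(Oc3ccnc(-c4nncn4CCN(C)C)c3)c(F)c2)c1` gives 1510 nM in a functional assay on MKN-45 cells (Homo sapiens) for cytotoxicity, read by MTT assay, with a stated time of 72 h; on this read-out higher numbers stand for weaker inhibition and lower numbers for stronger inhibition
compound 2 `CN(C)CCn1cnnc1-c1cc(Oc2ccc(NC(=O)N/N=C/c3ccc(O)c(Br)c3)cc2F)ccn1` gives 1860 nM in this assay
compound 3 `Cn1ncnc1-c1cc(Oc2ccc(NC(=O)N/N=C/c3ccccc3)cc2F)ccn1` sits at the limit > 100000 nM in this assay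

The value for compound 3 is a limit of the assay, not a number (the limit of > 100000 nM in this assay, at which 1 of the 3 values shown sits). Of the two numbers, compound 2 holds the higher one, separated from compound 1 by a 1.2-fold higher number from compound 1 to compound 2 (0.09 log units; within the scatter).

Compound 4 `CN(C)CCn1cnnc1-c1cc(Oc2ccc(NC(=O)N/N=C/c3ccc(O)c(F)c3)cc2F)ccn1` differs from compound 2 in one place: fluoro in place of bromo on an aromatic carbon. No measured step changes a halogen on this ring, so nothing shown bears directly on the swap; the only measured step, a 1.2-fold higher number from compound 1 to compound 2 (0.09 log units; within the scatter), replaced the whole aryl group and stayed within the scatter. The expectation is therefore a step of about a 1.3-fold higher number from compound 2 to compound 4 (0.13 log units; within the scatter), with no direction beyond the scatter. Compound 4 is estimated at 2500 nM, in the range 900 nM to 7000 nM.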

Compound 4, half-maximal inhibitory concentration: 1970 nM
For compound 4 the middle estimate is 1.3-fold (0.10 log units) above the measured one, within the range that was stated.
By their numbers in this assay, from the lowest: compounds 1, 2 and 4 (each within the scatter of the next). At a limit, above all of these: compound 3.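

In this assay, the change from 3-bromo-4-hydroxyphenyl to 3-fluoro-4-hydroxyphenyl gives a 1.1-fold higher number from compound 2 to compound 4 (0.02 log units; within the scatter), so this position, ortho to the hydroxy group, shows no separation between the two halogens. The fluoro compound also stays level with the 2,5-dimethoxyphenyl compound, at a 1.3-fold higher number from compound 1 to compound 4 (0.12 log units; within the scatter), so both aryl changes now lie within the scatter. No measured property shown bears on this swap.

Still open, going by these compounds, is whether a nitrile, an amine or a carboxylic acid in place of the halogen would leave the number equally unmoved. The role of the hydroxy group itself, with the halogen kept, also remains unresolved.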